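Amide nitrogen substituent series: step from compound 3 to compound 4

The source may report more compounds than this note shows. Statements on the series, on what has been measured and on what is new or still open speak of the compounds shown alone.

Three compounds share one core and differ only in the group on the amide-type nitrogen. In a functional assay on the whole organism for inhibition, with Mus musculus as the target, at a dose of 32 mg/kg by the oral route (a lower number here means less inhibition, a higher number more inhibition at the dose given (going by the name of the read-out)), compound 1 `CSc1ccc2c(c1)c(O)c(C(=O)N(C)c1ccccc1)c(=O)n2C` gives 100%, compound 2 `CSc1ccc2c(c1)c(O)c(C(=O)N(C)C1CCCCC1)c(=O)n2C` gives 43%, and compound 3 `CSc1ccc2c(c1)c(O)c(C(=O)N(C)c1ccccn1)c(=O)n2C` gives 65%. Compound 3 thus stands second highest of the three: the step of a number 22 percentage points higher from compound 2 to compound 3 (beyond the scatter) lies beyond the scatter, as does the step of a number 35 percentage points lower from compound 1 to compound 3 (beyond the scatter), so compound 1 sits clearly above it and compound 2 clearly below.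

Compound 4 `CSc1ccc2c(c1)c(O)c(C(=O)N(C)c1ccc(F)cc1)c(=O)n2C` has not been measured in this assay. The change is 4-fluorophenyl in place of pyridin-2-yl on an amide-type nitrogen. The step that bears on it most directly is a number 35 percentage points lower from compound 1 to compound 3 (beyond the scatter), since it is the same exchange in the reverse sense, with a fluorine added to the phenyl; the step of a number 57 percentage points lower from compound 1 to compound 2 (beyond the scatter) also shows the carbon-only phenyl at the top of this short set. An upward step of roughly that size is therefore expected, and for compound 4 the estimate is 88% with a range of 60% to 100%, meaning an expected step of a number 23 percentage points higher from compound 3 to compound 4 (beyond the scatter).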

Compound 4, a percentage reported as inhibition, in the whole organism at one dose (the size of the read-out at that dose, not a potency): 100%
Compound 4: middle estimate off by 12 percentage points, on the low side, within the range that was stated.
By their numbers in this assay, from the lowest: compound 2; then compound 3; then compounds 1 and 4 (each within the scatter of the next).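

In this assay, fluoro in place of hydrogen on an aromatic carbon leaves compound 1 and compound 4 indistinguishable at this dose (no change at the digits printed from compound 1 to compound 4 (within the scatter)), so this position accepts 4-fluorophenyl as well as phenyl. The other two steps (a number 35 percentage points higher from compound 3 to compound 4 (beyond the scatter) and a number 57 percentage points higher from compound 2 to compound 4 (beyond the scatter)) match in size those seen earlier for compound 1, which places both carbon-only aromatic groups clearly above pyridin-2-yl and cyclohexyl among these four compounds. No measurement at hand accounts for these differences.

Compound 1 and compound 4 share the same printed value, so these data do not separate the two groups at this single dose. As far as these compounds go, how an amine or a carboxylic acid on the phenyl ring, or a benzyl group on the amide-type nitrogen, would read remains open.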